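Swapping a butoxy for a fluoro on the aryl ketone

The compounds below may be only part of what the source reports. "The series", "measured", "known", "first", "only" and "open" are said of these compounds alone.

Of the compounds shown here, two of a shared core have been tested so far. Compound 1 `COc1ccc(/C=C/c2cc(OC)cc(OC)c2/C=C/C(=O)c2ccc(Cl)c(Cl)c2)cc1` and compound 2 `CCCCOc1ccc(C(=O)/C=C/c2c(/C=C/c3ccc(OC)cc3)cc(OC)cc2OC)cc1` differ only in the aromatic ring attached to the carbonyl carbon. In a functional assay on HepG2 cells (Homo sapiens) for antiproliferative activity, read by MTT assay, with a stated time of 48 h (on this read-out higher numbers stand for weaker inhibition and lower numbers for stronger inhibition), compound 1 gives 10.8 ug/mL, and in the same assay compound 2 gives 12.9 ug/mL. The step of a 1.2-fold higher number from compound 1 to compound 2 (0.08 log units; within the scatter) shows that replacing the 3,4-dichlorophenyl with a 4-butoxyphenyl barely moved the number, so compound 2 stands with compound 1, not apart from it.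

Compound 3 `COc1ccc(/C=C/c2cc(OC)cc(OC)c2/C=C/C(=O)c2ccc(F)cc2)cc1` is not yet measured. The change from compound 2 to compound 3 is fluoro in place of butoxy on an aromatic carbon, at the same ring on the carbonyl carbon that was already varied once. Among the compounds with values here, the one measured step that bears on this place, a 1.2-fold higher number from compound 1 to compound 2 (0.08 log units; within the scatter), was within the scatter, so a rather different substituent on this ring had little effect. On that basis the step of a 1.2-fold lower number from compound 2 to compound 3 (0.07 log units; within the scatter) is expected to be small, with no clear direction beyond the scatter. Compound 3 is therefore expected to give about 11 ug/mL, within a range of 5 ug/mL to 25 ug/mL in this assay.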

Compound 3, half-maximal inhibitory concentration: 12.2 ug/mL
The estimate for compound 3 lay 1.1-fold (0.04 log units) below the measured number; measured number inside the range.
By their numbers in this assay, from the lowest: compounds 1, 3 and 2 (each within the scatter of the next).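

In this assay, the step of a 1.1-fold lower number from compound 2 to compound 3 (0.02 log units; within the scatter) extends what the first pair suggested, this time with a sharper contrast: butoxy, a chain of 5 heavy atoms, gives way to fluoro, a single heavy atom, at the same place, para to a large group. The step of a 1.1-fold higher number from compound 1 to compound 3 (0.05 log units; within the scatter) adds that the 4-fluorophenyl cannot be told apart from the 3,4-dichlorophenyl either, so all three aryl ketones in this small set sit within the scatter of one another, and none of these groups on this ring separates from the others on this read-out. Nothing measured here explains why these exchanges leave the number in place.

As far as these compounds go, whether this tolerance extends to other kinds of group remains open: an amine or a carboxylic acid on this ring could behave quite differently from the butoxy, fluoro and chloro groups seen so far. The three compounds also share everything else, so they say nothing about how the number would respond to changes elsewhere on the shared core, such as replacing a methoxy group with a longer chain.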